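The compounds below may be only part of what the source reports. "The series", "measured", "known", "first", "only" and "open" are said of these compounds alone.

In an ADME assay on HeLa cells (Homo sapiens) for cytotoxicity, read by resazurin assay, with a stated time of 65 h (a higher number here means that more compound is needed for the effect, a lower number that less compound is needed), two compounds have been tested so far. Compound 1 `O=C(Nc1cccc(C(F)(F)F)c1)c1ccc([N+](=O)[O-])o1` gives > 20000 nM here, which is a limit of the assay and not a number. Compound 2 `O=C(Nc1ccc(O)c(C(F)(F)F)c1)c1ccc([N+](=O)[O-])o1` gives > 20000 nM here, again a limit and not a number. Compound 2 therefore stands at the limit of > 20000 nM in this assay, at which 2 of the 2 values shown sit, with no readable number of its own.

Compound 3 `C=CCOc1ccc(NC(=O)c2ccc([N+](=O)[O-])o2)cc1C(F)(F)F` takes compound 2 and turns hydroxy to allyloxy, with allyl in place of hydrogen on an oxygen on an aromatic ring is the whole difference. Among the compounds with values here, the only measured step is a step that the two limits leave unreadable from compound 1 to compound 2 and it offers no size that could be carried over to this new change. It also involves a different place on the molecule.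

With so little to go on, no step beyond the usual scatter is expected in this assay in either direction. The estimated size is a number no higher from compound 2 to compound 3 (the limit leaves the size open) and it rests only on the limit of compound 2. The assay may well report only a limit again. For compound 3 the expected value is 20000 nM with an estimated range from 7000 nM to 40000 nM in this read-out.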

Compound 3, half-maximal effective concentration: > 20000 nM
Compound 3 gave a limit, no number; the forecaster's own chance of this, stated with the estimate: 65%; the middle value lies on the limit itself.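

Compound 3 also gives a limit and not a number in this assay, so the steps among compound 1, compound 2 and compound 3 cannot be read: the limit of > 20000 nM in this assay, at which 3 of the 3 values shown sit. What stays open is what concentration of any of these compounds would reach the half-maximal effect, and whether allyloxy in place of hydroxy changes it at all.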